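Swapping Phenyl for Cyclobutyl on a Low-Read Compound

A few compounds are considered here, and "the series" means these few. Any claim that something is new, unique, unknown or untested is made for them only; others in the source may bear on it.

Compound 1 `O=c1nc(-c2ccccc2)c2cc(-c3cc[nH]n3)ccc2[nH]1` is the starting point here. Among the measured compounds shown here, in a physicochemical assay for solubility, measured as kinetic solubility (a higher number here means a more soluble compound, a lower number a less soluble compound), compound 1 gives 8000 nM, the only true number available so far. Compound 2 `O=c1nc(-c2ccccc2)c2cc(N3CCNCC3)ccc2[nH]1` reads > 1000000 nM, and this is a limit of the assay rather than a number. Compound 1 therefore has a single comparison, and that comparison is open-ended.

The next structure is compound 3 `O=c1nc(C2CCC2)c2cc(-c3cc[nH]n3)ccc2[nH]1`, where cyclobutyl takes the place of phenyl on an aromatic carbon, next to the ring nitrogen: cyclobutyl in place of phenyl on an aromatic carbon. The 1H-pyrazol-3-yl group stays as it was.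

For the measured compounds named here, the one measured step is an at least 120-fold higher number from compound 1 to compound 2 (2.09 log units; beyond the scatter), with piperazin-1-yl in place of 1H-pyrazol-3-yl on an aromatic carbon. That step is large, but it changed a different place from the one changed now, so its size does not carry over. The expectation rests on the structural change alone and is therefore cautious.

The expected change is a 2.5-fold higher number from compound 1 to compound 3 (0.40 log units; beyond the scatter), a modest rise in this assay. Compound 3 is estimated at 20000 nM, with an expected range of 6000 nM to 80000 nM.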

Compound 3, solubility: 74000 nM
Beside the measured number, compound 3's estimate is 3.7-fold (0.57 log units) below it, within the range that was stated.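

In this assay, among the compounds shown here, this is the first measured change at the place next to the ring nitrogen, and it gives a 9.3-fold higher number from compound 1 to compound 3 (0.97 log units; beyond the scatter). So this place on the shared core can also move the read-out beyond the usual scatter, not only the place holding the 1H-pyrazol-3-yl group, and it does so with no hydrogen-bond donor, hydrogen-bond acceptor or net charge on either the leaving phenyl or the entering cyclobutyl. Nothing measured here gives a reason for the rise.

With a single replacement at this place, the compounds shown cannot separate the loss of the aromatic ring from the drop in heavy atoms, and a cyclohexyl ring or a straight butyl chain in the same place would help tell those two readings apart. Going by these compounds, it also stays open whether an amine at this place, such as piperidin-4-yl, would go further, and whether cyclobutyl would still bring a rise on a core carrying piperazin-1-yl in place of 1H-pyrazol-3-yl.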